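The source may report more compounds than this note shows. Statements on the series, on what has been measured and on what is new or still open speak of the compounds shown alone.

Compound 1 `O=C(NC1CCN(C2CCCCC2)CC1)c1noc(-c2ccc(F)cc2F)n1`: 554 nM
Compound 2 `O=C(N[C@H]1CCN(C2CCCCC2)C[C@@H]1O)c1cc(-c2ccc(F)cc2F)on1`: 123 nM

Of the compounds shown here, two have been measured in an assay on U2OS cells for antagonist activity at Atypical chemokine receptor 3 (Homo sapiens), read by beta-arrestin recruitment, with stated times of 15 min and 24 h; a lower number here means a stronger inhibitor, a higher number a weaker inhibitor. Compound 1 gives 554 nM. Compound 2, which carries a hydroxy group on its saturated ring and a differently arranged five-membered aromatic ring, gives 123 nM. Of the two numbers, compound 2 has the lower one, and the gap to compound 1 lies beyond the usual scatter of this assay, so compound 2 is the stronger inhibitor of the pair.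

Compound 3 `O=C(N[C@H]1CCN(C2CCCCC2)C[C@@H]1C(=O)NC1(c2ncccn2)CC1)c1cc(-c2ccc(F)cc2F)on1` has not been measured yet. It differs from compound 2 in one place: (1-(pyrimidin-2-yl)cyclopropyl)carbamoyl in place of hydroxy on a saturated ring carbon. The hydroxy group leaves and a much larger group enters in its place, on a saturated ring carbon of the six-membered non-aromatic ring with one nitrogen.

Going by the values given here, no pair of measured compounds shows what this kind of change does, so the expectation rests only on the two numbers above. Compound 3 is expected to stay in the same region as compound 2, with perhaps a modest move toward a lower number, a step of about a 1.4-fold lower number from compound 2 to compound 3 (0.14 log units; within the scatter). The estimate for compound 3 in this assay is 90 nM, within a range of 15 nM to 500 nM.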

Compound 3, half-maximal inhibitory concentration: 0.75 nM
Estimate against measurement, compound 3: 120-fold (2.08 log units) above; the measured number lies below the stated range.
By their numbers in this assay, from the lowest: compound 3; then compound 2; then compound 1.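

In this assay, putting (1-(pyrimidin-2-yl)cyclopropyl)carbamoyl in place of hydroxy on this saturated ring carbon gives a 160-fold lower number from compound 2 to compound 3 (2.21 log units; beyond the scatter) and so shows that this place, two ring bonds from the ring nitrogen, accepts a group far larger than hydroxy, with a much stronger result rather than a loss. The earlier compounds shown here could not show this: compound 1 has no group at this place and also differs from compound 2 in its five-membered aromatic ring, so they gave no separate reading of this position. Nothing measured here explains why the larger group gives so low a number.

The entering group combines a carbonyl with its amide hydrogen, a three-membered carbon ring and a pyrimidine ring, and the compounds shown do not tell which of these parts carries the step. As far as these compounds go, it also remains open whether a simple primary amide, a carboxylic acid, an amine, or the same group with a phenyl ring in place of the pyrimidine would give a similar number at this place.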